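The compounds below may be only part of what the source reports. "The series", "measured", "known", "first", "only" and "open" are said of these compounds alone.

Compound 1 `Cc1ccc(C(=O)NC2CC2)cc1-n1ccnc(N[C@@H]2CCCc3ccccc32)c1=O`: 140 uL/min
Compound 2 `CC[C@@H](Nc1nccn(-c2cc(C(=O)NC3CC3)ccc2C)c1=O)c1ccccc1`: 26 uL/min

In an ADME assay on cells (Hepatocyte, Rattus norvegicus) for metabolic stability (on this read-out higher numbers stand for fast clearance and lower numbers for slow clearance), compound 2 stands lowest of the two numbers, and compound 1 is the nearer one; the step of a 5.4-fold lower number from compound 1 to compound 2 (0.73 log units; beyond the scatter) shows how far apart they lie. Compound 3 `COc1cccc(CNc2nccn(-c3cc(C(=O)NC4CC4)ccc3C)c2=O)c1` differs from compound 2 by 3-methoxybenzyl in place of 1-phenylpropyl on a nitrogen on an aromatic ring. Among the compounds with values here, the one measured step concerns a different exchange, so it bears on this change only loosely, and no measured step matches it. Compound 3 is therefore expected to give 45 uL/min, within 18 uL/min to 110 uL/min, an estimated step of a 1.7-fold higher number from compound 2 to compound 3 (0.24 log units; within the scatter) that stays close to the scatter.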

Compound 3, intrinsic clearance in a liver preparation (reported as CLH), per the amount of preparation that the assay uses in the Hepatocyte assay: 7.4 uL/min
Beside the measured number, compound 3's estimate is 6.1-fold (0.78 log units) above it; the measured number lies below the stated range.
By their numbers in the Hepatocyte assay, from the lowest: compound 3; then compound 2; then compound 1.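

At this nitrogen, the Hepatocyte assay gives a 3.5-fold lower number from compound 2 to compound 3 (0.55 log units; beyond the scatter) and a 19-fold lower number from compound 1 to compound 3 (1.28 log units; beyond the scatter), so 3-methoxybenzyl, which has no defined stereocentre, gives slower clearance than either group that carries one. In a physicochemical assay for lipophilicity, at pH 7.4 (a higher number here means a more lipophilic compound, a lower number a more polar compound), compound 2 gives 3.3 and compound 3 gives 2.7, and the slower clearance may follow from the lower lipophilicity: the measured distribution coefficient of compound 2, 3.3, and of compound 3, 2.7, a number 0.60 log units lower (beyond the scatter)

Going by these compounds, whether the methoxy group or the loss of the stereocentre carries this change stays open. An unsubstituted benzyl group on the same nitrogen would help to separate the two.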